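The source may hold more compounds than are shown below. What is called first, only, known or untested is meant among the compounds shown, and "the series" means these compounds.

Of the compounds shown here, two sharing one core have been tested so far. Compound 1 `CCc1ccc(C(=O)Nc2cccc(-c3oc4cc(-c5ccc(F)cc5)ccc4c(=O)c3O)c2)cc1` gives 18500 nM in a functional assay on A549 cells (Homo sapiens) for antiproliferative activity, read by CCK-8 assay, with a stated time of 72 h; on this read-out lower numbers stand for stronger inhibition and higher numbers for weaker inhibition. Compound 2 `Cc1cc(C(=O)Nc2cccc(-c3oc4cc(-c5ccc(F)cc5)ccc4c(=O)c3O)c2)ccc1F` gives 11500 nM in this assay. Going by the values given here, the single step between them, a 1.6-fold lower number from compound 1 to compound 2 (0.21 log units; within the scatter), does not reach beyond the scatter, so compound 2 and compound 1 cannot be told apart on these two numbers; compound 2 simply has the lower of two numbers that sit within the scatter of each other.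

Compound 3 `COc1ccc(C(=O)Nc2cccc(-c3oc4cc(-c5ccc(F)cc5)ccc4c(=O)c3O)c2)c(F)c1` is not yet measured. It differs from compound 2 in one place: 2-fluoro-4-methoxyphenyl in place of 4-fluoro-3-methylphenyl on a carbonyl carbon. Among the compounds with values here, this is the same kind of change as the one step already seen, a swap of the substitution pattern on the aromatic ring attached to the carbonyl carbon, and that step, a 1.6-fold lower number from compound 1 to compound 2 (0.21 log units; within the scatter), stayed within the scatter. Within the data shown here, with only this one step to go on, no shift beyond the scatter is expected in this assay, in either direction. Compound 3 is therefore estimated at 12000 nM, with a range from 5000 nM to 30000 nM, which means an expected step of a 1.0-fold higher number from compound 2 to compound 3 (0.02 log units; within the scatter).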

Compound 3, half-maximal inhibitory concentration: 40000 nM
For compound 3 the middle estimate is 3.3-fold (0.52 log units) below the measured one, and the stated range ends below it.
By their numbers in this assay, from the lowest: compounds 2 and 1 (each within the scatter of the next); then compound 3.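

The swap of the aromatic group on the carbonyl carbon now has a measurable effect in this assay: placing 2-fluoro-4-methoxyphenyl there in place of 4-fluoro-3-methylphenyl gives a 3.5-fold higher number from compound 2 to compound 3 (0.54 log units; beyond the scatter), and placing it there in place of 4-ethylphenyl gives a 2.2-fold higher number from compound 1 to compound 3 (0.33 log units; beyond the scatter). The earlier pair could not be told apart, so that step alone might have suggested that this position tolerates changes to the ring, but both new steps run towards weaker inhibition, showing that the choice of group here can matter, if only modestly. Nothing available explains why this group behaves differently from the other two.

The compounds shown leave open whether the step follows from the methoxy group or from where the fluorine stands, as 2-fluoro-4-methoxyphenyl differs from 4-fluoro-3-methylphenyl in both respects, and a 2-fluorophenyl or 4-methoxyphenyl group would separate the two. They also leave open how this position responds to a quite different kind of group on the ring, such as an amine or a carboxylic acid.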